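Phenyl in place of dimethylamino at two placements

The source may hold more compounds than are shown below. What is called first, only, known or untested is meant among the compounds shown, and "the series" means these compounds.

Measured in an assay on isolated protein for displacement of a labelled ligand from 5-hydroxytryptamine receptor 6 (Homo sapiens), read by scintillation counting, with a stated time of 1 h; a lower number here means a stronger inhibitor, a higher number a weaker inhibitor:
compound 1, `CN(C)c1cn(S(=O)(=O)c2ccccc2)c2ccccc12`: 474 nM
compound 2, `O=S(=O)(c1ccccc1)n1cc(-c2ccccc2)c2ccccc21`: 146 nM
compound 3, `CN(C)c1cccc2c1ccn2S(=O)(=O)c1ccccc1`: 65 nM

Compound 3 has the same atoms as compound 1, joined differently; the difference between the two cores is not broken down here. Compound 3 gives the lowest of the three numbers, and its steps to compound 2 and compound 1 both lie beyond the scatter.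

Compound 2 differs from compound 1 by phenyl in place of dimethylamino on an aromatic carbon, and the step is a 3.2-fold lower number from compound 1 to compound 2 (0.51 log units; beyond the scatter).

Compound 4, `O=S(=O)(c1ccccc1)n1ccc2c(-c3ccccc3)cccc21`, is not yet measured. It differs from compound 3 by phenyl in place of dimethylamino on an aromatic carbon. This is the same kind of change as from compound 1 to compound 2, not the same: there the place is on an aromatic carbon of a five-membered aromatic ring with 1 nitrogen, two ring bonds from the ring nitrogen; here it is on an aromatic carbon of a six-membered aromatic ring of carbon only, ortho to a fused ring and meta to a fused ring.

Within the data shown here, only one measured example of the change exists, at a different place, so the expectation is a smaller step than that one: from compound 3 to compound 4 a step of a 1.9-fold lower number from compound 3 to compound 4 (0.27 log units; within the scatter) is expected in this assay, because compound 1 to compound 2 gave a 3.2-fold lower number from compound 1 to compound 2 (0.51 log units; beyond the scatter). Compound 4 is therefore estimated at 35 nM, between 12 nM and 110 nM.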

Compound 4, inhibition constant: 162 nM
For compound 4 the middle estimate is 4.6-fold (0.67 log units) below the measured one, outside the stated range (above it).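

In this assay, phenyl in place of dimethylamino gives a 2.5-fold higher number from compound 3 to compound 4 (0.40 log units; beyond the scatter), the opposite direction to the step on the core of compound 1. The change therefore cannot be carried from one core to the other in this series as a fixed step, and the two results differ in direction and in size: the same change on two cores in this assay, a 3.2-fold lower number (0.51 log units; beyond the scatter) from compound 1 to compound 2 and a 2.5-fold higher number (0.40 log units; beyond the scatter) from compound 3 to compound 4, 8.1-fold (0.91 log units) apart, beyond the scatter of two such steps. This shows that the outcome of the change depends on the core or the place it occupies, but two pairs cannot separate those two factors, give a reason for the reversal or support a rule for any further core.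

The compounds shown leave open how other groups on the same aromatic carbons would compare with dimethylamino and phenyl, for example a primary amine, a methoxy group, a piperidine ring or a pyridine ring. They also leave open whether such groups would split the two placements in the same way, or whether this reversal is particular to the exchange of phenyl for dimethylamino.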